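This account rests on a few compounds, and the source may have more. Where it says the series, first, only, none or still open, it means among the compounds named here.

Working notes on the thiourea series. Compound 1, `S=C(Nc1ccccc1)N1N=C(c2ccccc2)CC1c1ccc2c(c1)OCCO2`, is the unsubstituted phenyl member and gives 1850 nM in a functional assay on A-375 cells (Homo sapiens) for antiproliferative activity, read by MTT assay, with a stated time of 48 h; a higher number here means a weaker inhibitor of growth, a lower number a stronger inhibitor of growth. Compound 3, `COc1ccccc1C1=NN(C(=S)Nc2ccccc2)C(c2ccc3c(c2)OCCO3)C1`, carries a methoxy on that phenyl and gives 20300 nM in this assay, which is the highest of the two numbers shown; the nearest is compound 1, through an 11-fold higher number from compound 1 to compound 3 (1.04 log units; beyond the scatter). Compound 2, `S=C(Nc1ccccc1)N1N=C(c2ccccc2Br)CC1c1ccc2c(c1)OCCO2`, with a bromo on the same phenyl, gives > 200000 nM in this assay, which is a limit of the assay and not a number, as recorded in the limit of > 200000 nM in this assay, at which 1 of the 3 values shown sits. The bromo step is an at least 100-fold higher number from compound 1 to compound 2 (2.03 log units; beyond the scatter), and the step back to the methoxy member is an at least 9.8-fold lower number from compound 2 to compound 3 (0.99 log units; beyond the scatter).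

Compound 4, `S=C(Nc1ccccc1)N1N=C(c2cccc(Cl)c2)CC1c1ccc2c(c1)OCCO2`, has not been measured in this assay. It differs from compound 3 by 3-chlorophenyl in place of 2-methoxyphenyl on a carbon with a double bond to nitrogen. Among the measured compounds shown here, no measured step places a chlorine at that position, so the expectation rests on the two substitutions on the same phenyl that are known: both raised the number beyond the scatter, and the halogen one most of all. Compound 4 is therefore expected to give roughly 12000 nM in this assay, within 1500 nM to 150000 nM, which would be an estimated step of a 1.7-fold lower number from compound 3 to compound 4 (0.23 log units; within the scatter); a limit result cannot be excluded.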

Compound 4, concentration for 50% growth inhibition: > 200000 nM
Compound 4: only a limit was reported; the forecaster's own chance of this, stated with the estimate: 20%; middle value at least 16-fold (1.22 log units) away from the limit.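

Among the compounds shown here, a chlorine on the phenyl gives an at least 100-fold higher number from compound 1 to compound 4 (2.03 log units; beyond the scatter), so in this assay all three substituted phenyl members, compounds 2, 3 and 4, stand beyond the scatter above the unsubstituted compound 1. 3-Chlorophenyl in place of 2-methoxyphenyl gives an at least 9.8-fold higher number from compound 3 to compound 4 (0.99 log units; beyond the scatter), which leaves compound 3 as the only substituted member here with a readable number, and the loss is now seen with a halogen in two different places on the phenyl, as 2-bromophenyl and as 3-chlorophenyl. The value of compound 4 is a limit of the assay and not a number, and compound 2 sits at the same limit, so the step between them cannot be read and the two halogen members cannot be ranked: the limit of > 200000 nM in this assay, at which 2 of the 4 values shown sit.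

Going by these compounds, it remains open whether a 2-chlorophenyl or a 3-methoxyphenyl group would separate the effect of the place on the phenyl from that of the substituent itself. On these data alone, it is also open whether an amine, a hydroxy or a carboxylic acid on this phenyl would give a number near that of compound 1 or fall away in the same manner.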